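This account rests on a few compounds, and the source may have more. Where it says the series, first, only, none or still open, it means among the compounds named here.

Measured in a functional assay on CAL-51 cells (Homo sapiens) for inhibition, read by sulforhodamine B assay, with a stated time of 3 days; on this read-out lower numbers stand for stronger inhibition of growth and higher numbers for weaker inhibition of growth:
compound 1 `O=C(/C=C/c1ccccc1)c1ccc(OCc2ccccc2)cc1`: 28900 nM
compound 2 `COc1cccc(/C=C/C(=O)c2ccc(OCc3ccccc3)cc2)c1`: 13700 nM
compound 3 `Cc1ccc(COc2ccc(C(=O)/C=C/c3ccc(Cl)cc3)cc2)cc1`: > 50000 nM

Compound 3 has no number on this scale, and its > 50000 nM is only a limit. The ceiling matters for what follows: the limit of > 50000 nM in this assay, at which 1 of the 3 values shown sits.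

The next compound is compound 4 `O=C(/C=C/c1ccc(Cl)cc1)c1ccc(OCc2ccccc2)cc1`, which is compound 3 with hydrogen in place of methyl on an aromatic carbon, para to a large group, so that 4-methylbenzyl becomes benzyl (hydrogen in place of methyl on an aromatic carbon). Among the compounds with values here, no measured step tests this change directly. The only one available, a 2.1-fold lower number from compound 1 to compound 2 (0.32 log units; beyond the scatter), is modest and involves a different change, methoxy in place of hydrogen. It suggests that single substitutions in this small set can shift growth inhibition modestly. Compound 1 reads 28900 nM and compound 2 reads 13700 nM, so numbers in this range can be reached. A modest move toward a lower number is therefore expected, though compound 4 may also stay at the limit. The expected change is an at least 1.6-fold lower number from compound 3 to compound 4 (0.22 log units; that floor lies within the scatter). For compound 4 the estimated value is 30000 nM, with an expected range of 13000 nM to 50000 nM.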

Compound 4, concentration for 50% growth inhibition: > 50000 nM
Compound 4: no number, only a limit (the forecaster's own chance of this, stated with the estimate: 35%); at least 1.6-fold (0.22 log units) between middle value and limit.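

In this assay, from the compounds shown here alone, compound 4 has only a limit and not a number, as compound 3 does, so going from 4-methylbenzyl to benzyl leaves both 4-chlorophenyl compounds at the ceiling: the limit of > 50000 nM in this assay, at which 2 of the 4 values shown sit. The step between these two cannot be read, and the effect of hydrogen in place of methyl at this position remains unknown. Compound 4 can still be set against the two compounds with numbers, giving an at least 3.6-fold higher number from compound 2 to compound 4 (0.56 log units; beyond the scatter) for 4-chlorophenyl in place of 3-methoxyphenyl and an at least 1.7-fold higher number from compound 1 to compound 4 (0.23 log units; that floor lies within the scatter) for chloro in place of hydrogen, so only the first of these clearly exceeds the scatter.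

Going by these compounds, it remains open whether an amine or a carboxylic acid in place of the methyl of compound 3 would give a readable number. On these data alone, it is equally open whether a nitrile in place of the chloro of compound 4 would do so.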